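Swapping Fluoro for Iodo on the Core of Compound 2

A few compounds are considered here, and "the series" means these few. Any claim that something is new, unique, unknown or untested is made for them only; others in the source may bear on it.

Compound 1 `O=C(O)/C(S)=C/c1ccc(Br)cc1` and compound 2 `O=C(O)/C(S)=C/c1c[nH]c2cc(F)ccc12` share the same acid-bearing chain and differ in the aromatic part attached to it. In an assay on isolated protein for inhibition of Calpain-1 catalytic subunit (Sus scrofa) (a higher number here means a weaker inhibitor, a lower number a stronger inhibitor), compound 1 gives 1500 nM, while compound 2 gives 300 nM, the lower of the two numbers, and the gap between them lies beyond the usual scatter. Compound 3 `O=C(O)/C(S)=C/c1c[nH]c2cc(I)ccc12` keeps the core of compound 2 and differs from it in one place: iodo in place of fluoro on an aromatic carbon. Within the data shown here, no measured pair shows what such a halogen exchange does on this core, so the direction of the step is open. Among the measured compounds shown here, the only anchor is compound 2 with its value of 300 nM in this assay. For compound 3 the expected step of no change at the digits printed from compound 2 to compound 3 (within the scatter) stays within the usual scatter, in no clear direction. Compound 3 is therefore estimated to give about 300 nM in this assay, with a likely range from 80 nM to 1200 nM.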

Compound 3, half-maximal inhibitory concentration: 300 nM
Beside the measured number, compound 3's estimate shows no gap at the digits printed; the measured number falls inside the stated range.
By their numbers in this assay, from the lowest: compounds 2 and 3 (each within the scatter of the next); then compound 1.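

In this assay, among these compounds, iodo in place of fluoro on the aromatic carbon gives no change at the digits printed from compound 2 to compound 3 (within the scatter), the first measured reading of a halogen exchange on this core. At this place, meta to a fused ring and para to a fused ring, the two halogens therefore give values within the scatter of each other, so this one exchange does not separate them. Nothing measured here explains this result.

Going by these compounds, what a group other than a halogen would do at this place remains open, whether an amine, a methoxy group or a nitrile, and so does the value with plain hydrogen there. The compounds shown also leave open whether an amide could stand in place of the carboxylic acid on the shared chain.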